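A Flat Series Meets a Methyl-for-Methoxy Swap

The compounds below may be only part of what the source reports. "The series", "measured", "known", "first", "only" and "open" are said of these compounds alone.

Of the compounds shown here, three sharing one core have been measured in an in vitro functional assay on cells for agonist activity at Bombesin receptor subtype-3 (Homo sapiens), read by luminescence and calcium flux; on this read-out lower numbers stand for an effect already at smaller amounts and higher numbers for an effect only at larger amounts of compound. Compound 1 `O=C(O)c1ccccc1-c1ccc(CCc2ncc(-c3ccccc3)[nH]2)cc1` gives 4950 nM. Compound 2 `CC(C)(C)c1cnc(CCc2ccc(-c3ccccc3C(=O)O)cc2)[nH]1`, carrying tert-butyl in place of phenyl on an aromatic carbon, gives 4330 nM, a change of a 1.1-fold lower number from compound 1 to compound 2 (0.06 log units; within the scatter). Compound 3 `COc1cccc(Cc2cnc(CCc3ccc(-c4ccccc4C(=O)O)cc3)[nH]2)c1`, with 3-methoxybenzyl in place of phenyl, gives 4120 nM; the steps to it are a 1.2-fold lower number from compound 1 to compound 3 (0.08 log units; within the scatter) and a 1.1-fold lower number from compound 2 to compound 3 (0.02 log units; within the scatter). Compound 3 thus carries the lowest of the three numbers, yet every step to it lies within the scatter, so no ordering among the three can be claimed.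

Compound 4 `Cc1ccccc1Cc1cnc(CCc2ccc(-c3ccccc3C(=O)O)cc2)[nH]1` differs from compound 3 on a saturated chain carbon bound to an aromatic carbon: 2-methylphenyl in place of 3-methoxyphenyl on a saturated chain carbon bound to an aromatic carbon. The three measured steps, all within the scatter, bear on it only in that varying this part of the molecule has so far left the read-out unchanged. Compound 4 is therefore expected to show a 1.0-fold higher number from compound 3 to compound 4 (0.02 log units; within the scatter), a step within the scatter. The estimate for compound 4 is 4300 nM, with a range from 2000 nM to 9000 nM.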

Compound 4, half-maximal effective concentration: 127 nM
Beside the measured number, compound 4's estimate is 34-fold (1.53 log units) above it; the whole stated range lies above it.
By their numbers in this assay, from the lowest: compound 4; then compounds 3, 2 and 1 (each within the scatter of the next).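

In this assay, this position proves far from indifferent, although the earlier changes had all stayed within the scatter: 2-methylphenyl in place of 3-methoxyphenyl on a saturated chain carbon bound to an aromatic carbon gives a 32-fold lower number from compound 3 to compound 4 (1.51 log units; beyond the scatter). The other two comparisons give a 34-fold lower number from compound 2 to compound 4 (1.53 log units; beyond the scatter) and a 39-fold lower number from compound 1 to compound 4 (1.59 log units; beyond the scatter), so a substituted benzyl group at this place is not enough by itself, as 3-methoxybenzyl and 2-methylbenzyl give widely separated numbers. No supporting data are available to explain the size of this step.

The compounds shown do not separate the arrival of the methyl, the departure of the methoxy and the place of each on the ring, as this one change alters all three together. They also leave open how an unsubstituted benzyl group, or an ethyl group or a chlorine in place of the methyl, would read out here.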